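This account rests on a few compounds, and the source may have more. Where it says the series, first, only, none or still open, it means among the compounds named here.

Compound 1 `CCOc1cc(=O)n(CCCO)c2c1CC(C/C=C(\C)CCC=C(C)C)C(C)(C)C2` gives 67.8% in a functional assay on PANC-1 cells (Homo sapiens) for inhibition, read by MTT assay, with a stated time of 24 h, tested at 10 uM; a higher number here means more inhibition at the concentration tested (going by the name of the read-out), a lower number less inhibition. Compound 2 `CC(C)=CCC/C(C)=C/CC1Cc2c(OCCCNC(=O)c3ccco3)cc(=O)n(CCCO)c2CC1(C)C` gives 69.5% in this assay.

Compound 2 stands as the higher of the two numbers shown, but its nearest neighbour is compound 1, and the step of a number 1.7 percentage points higher from compound 1 to compound 2 (within the scatter) lies within the scatter. Compound 3 `CC(C)=CCC/C(C)=C/CC1Cc2c(OCCCOc3ccc(Cl)cc3)cc(=O)n(CCCO)c2CC1(C)C` differs from compound 2 by 4-chlorophenoxy in place of ((furan-2-yl)carbonyl)amino on a saturated chain carbon, three bonds along the chain from an oxygen on an aromatic ring. Within the data shown here, no measured step bears directly on this exchange; the one step known shows that adding a group at the end of this chain left the read-out essentially unchanged. He therefore expects no step beyond the scatter, a number 3.5 percentage points lower from compound 2 to compound 3 (within the scatter), and estimates compound 3 at 66%, in the range 48% to 82%.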

Compound 3, a percentage reported as inhibition, at one concentration (the size of the read-out at that concentration, not a potency): 25.2%
Estimate against measurement, compound 3: 40.8 percentage points above, and the stated range ends above it.
By their numbers in this assay, from the lowest: compound 3; then compounds 1 and 2 (each within the scatter of the next).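

At the end of this chain the group clearly matters: in this assay 4-chlorophenoxy in place of ((furan-2-yl)carbonyl)amino gives a number 44.3 percentage points lower from compound 2 to compound 3 (beyond the scatter) and thus reverses the flat picture left by the earlier step. Measured against the hydrogen of compound 1, (4-chlorophenoxy)methyl gives a number 42.6 percentage points lower from compound 1 to compound 3 (beyond the scatter) while the furan amide chain does not, so the position accepts one added group and not the other. Nothing available explains this difference. The compounds shown leave open whether the drop follows the chlorine, the phenoxy oxygen or the loss of the amide. An unsubstituted phenoxy or a benzoylamino group on the same chain would help separate these.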